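A Larger Nitrogen Substituent on a Shared Core

The compounds below may be only part of what the source reports. "The series", "measured", "known", "first", "only" and "open" are said of these compounds alone.

Of the compounds shown here, three sharing one core have been measured in a functional assay (trachea) with Cavia porcellus as the target; a higher number here means a weaker inhibitor, a lower number a stronger inhibitor. Compound 1 `CCCn1nc(-c2cccnc2)c2ccccc2c1=O` gives 3160 nM in this assay. Compound 2 `CC(C)n1nc(-c2cccnc2)c2ccccc2c1=O` gives 3090 nM, and compound 3 `C=CCn1nc(-c2cccnc2)c2ccccc2c1=O` gives 2140 nM. Among these three numbers compound 2 stands second highest; its nearest neighbour is compound 1 and its furthest is compound 3, and both of those gaps lie within the scatter, so no ordering can be read from them.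

The change now under consideration goes from compound 2 to compound 4 `O=c1c2ccccc2c(-c2cccnc2)nn1CCSc1nccs1`: 2-((1,3-thiazol-2-yl)sulfanyl)ethyl in place of isopropyl on an aromatic nitrogen. The measured steps all touch the same aromatic nitrogen, but with small groups only: a 1.0-fold lower number from compound 1 to compound 2 (0.01 log units; within the scatter), a 1.5-fold lower number from compound 1 to compound 3 (0.17 log units; within the scatter) and a 1.4-fold lower number from compound 2 to compound 3 (0.16 log units; within the scatter). None of them reaches beyond the scatter, so the numbers tell that small changes at this position barely move this assay. Nothing measured speaks to a 2-((1,3-thiazol-2-yl)sulfanyl)ethyl group or to any substituent of comparable size there, and the expectation therefore rests on the insensitivity seen so far, widened for the unexplored size of the new group. Compound 4 is estimated at 1800 nM, within a range of 350 nM to 7000 nM, which means an expected step of a 1.7-fold lower number from compound 2 to compound 4 (0.23 log units; within the scatter).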

Compound 4, half-maximal inhibitory concentration: 10500 nM
Beside the measured number, compound 4's estimate is 5.8-fold (0.77 log units) below it, outside the stated range (above it).
By their numbers in this assay, from the lowest: compounds 3, 2 and 1 (each within the scatter of the next); then compound 4.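

At this position the insensitivity seen with small groups does not hold: in this assay the 2-((1,3-thiazol-2-yl)sulfanyl)ethyl group in place of isopropyl gives a 3.4-fold higher number from compound 2 to compound 4 (0.53 log units; beyond the scatter), and set against the other small substituents the same group gives a 4.9-fold higher number from compound 3 to compound 4 (0.69 log units; beyond the scatter) and a 3.3-fold higher number from compound 1 to compound 4 (0.52 log units; beyond the scatter). All three steps lie beyond the scatter and run in the same direction, so compound 4 is the weakest inhibitor of the four, and the aromatic nitrogen is shown to be a place where a substituent can move this assay, though only modestly and only toward a weaker inhibitor. Nothing available here accounts for this rise, and the reason for it remains unknown.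

Compound 4 brings in a longer chain, a sulfur atom and a five-membered aromatic ring all at once, so the compounds shown cannot say which of these parts goes with the higher number. From the compounds shown here alone, how a plain pentyl chain, a benzyl group or a 2-hydroxyethyl group would stand in this assay remains open, and with it whether size alone separates compound 4 from the small groups.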